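Methoxy for Acetamido: Another Step Expected at the Limit

The source may hold more compounds than are shown below. What is called first, only, known or untested is meant among the compounds shown, and "the series" means these compounds.

Of the compounds shown here, three have been tested in an ADME assay on HUVEC cells (Homo sapiens) for antiproliferative activity, read by MTT assay, with a stated time of 48 h; on this read-out lower numbers stand for stronger inhibition and higher numbers for weaker inhibition. Compound 1 `COc1ccc(-n2nncc2CN2C(=O)C3(C(C#N)=C(N)Oc4c3c3nc5ccccc5nc3c3ccccc43)c3ccccc32)cc1` gives only a limit, > 50000 nM. Compound 2 `CC(=O)Nc1ccc(-n2nncc2CN2C(=O)C3(C(C#N)=C(N)Oc4c3c3nc5ccccc5nc3c3ccccc43)c3ccccc32)cc1` likewise gives only a limit, > 50000 nM. Compound 3 `CC(=O)Nc1ccc(-n2nncc2CN2C(=O)C3(C(C#N)=C(N)Oc4c(N)cc5nc6ccccc6nc5c43)c3ccccc32)cc1` also gives only a limit, > 50000 nM. The change from compound 2 to compound 1 is methoxy in place of acetamido on an aromatic carbon, and the step it made, a step that the two limits leave unreadable from compound 2 to compound 1, cannot be read because of the limit of > 50000 nM in this assay, at which 3 of the 3 values shown sit. Compound 4 `COc1ccc(-n2nncc2CN2C(=O)C3(C(C#N)=C(N)Oc4c(N)cc5nc6ccccc6nc5c43)c3ccccc32)cc1` carries the same change on the core of compound 3, namely (methoxy in place of acetamido on an aromatic carbon); how the core of compound 3 differs from the core of compound 2 is not broken down here. Since (the limit of > 50000 nM in this assay, at which 3 of the 3 values shown sit), the step expected in this assay, a step that the limit leaves unreadable from compound 3 to compound 4, is estimated to stay unreadable as well. Compound 4 is therefore expected to give about 60000 nM, most likely again only as a limit, within a range from 20000 nM to 200000 nM.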

Compound 4, half-maximal inhibitory concentration: > 50000 nM
Compound 4: a limit, no number; the forecaster's own chance of this, stated with the estimate: 85%; the middle value lies beyond the limit too.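

No new step can be read from compound 3 to compound 4, because both values are only limits: the limit of > 50000 nM in this assay, at which 4 of the 4 values shown sit.

The compounds shown leave open whether methoxy in place of acetamido changes the activity at all, on either core.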